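The compounds below may be only part of what the source reports. "The series", "measured", "known", "first", "only" and "open" are said of these compounds alone.

Measured so far: compound 1 `O=[N+]([O-])c1cccc(COc2ccc(OCCOCCNC3CCCC3)cc2)c1`, compound 2 `Nc1ccccc1COc1ccc(OCCOCCNC2CCCC2)cc1` and compound 3 `O=C(O)c1ccc(COc2ccc(OCCOCCNC3CCCC3)cc2)cc1`. In a functional assay on SK-OV-3 cells (Homo sapiens) for inhibition, read by CCK-8 assay, with a stated time of 70 h (on this read-out lower numbers stand for stronger inhibition and higher numbers for weaker inhibition), compound 1 gives 15400 nM. In this assay compound 2 gives 14000 nM. For compound 3 this assay reports > 100000 nM, which is a limit of the assay rather than a number (the limit of > 100000 nM in this assay, at which 1 of the 3 values shown sits).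

Compound 3 thus stands at the weak end of the three, its steps from compound 1 and compound 2 both beyond the scatter. Compound 4 `Cc1ccc(COc2ccc(OCCOCCNC3CCCC3)cc2)cc1` differs from compound 3 in one place: methyl in place of carboxy on an aromatic carbon. Going by the values given here, no measured step exchanges carboxy for methyl; the steps that bear on it are those into compound 3, an at least 6.4-fold higher number from compound 1 to compound 3 (0.81 log units; beyond the scatter) and an at least 7.1-fold higher number from compound 2 to compound 3 (0.85 log units; beyond the scatter). Taking the carboxy group away is therefore expected to bring the number back toward those of compound 1 and compound 2, a step of an at least 6.6-fold lower number from compound 3 to compound 4 (0.82 log units; beyond the scatter). Compound 4 is estimated at 15000 nM, between 5000 nM and 60000 nM.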

Compound 4, half-maximal inhibitory concentration: 17200 nM
Compound 4: middle estimate off by 1.1-fold (0.06 log units), on the low side; the measured number falls inside the stated range.
By their numbers in this assay, from the lowest: compounds 2, 1 and 4 (each within the scatter of the next). At a limit, above all of these: compound 3.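

Methyl in place of carboxy on the same aromatic carbon, para to a large group, gives a clear recovery (an at least 5.8-fold lower number from compound 3 to compound 4 (0.76 log units; beyond the scatter)), so the weak result of compound 3 goes with the carboxy group and not with any substituent on this carbon. Compound 4 also sits level with the other two (a 1.2-fold higher number from compound 2 to compound 4 (0.09 log units; within the scatter); a 1.1-fold higher number from compound 1 to compound 4 (0.05 log units; within the scatter)), so 4-methylphenyl, 2-aminophenyl and 3-nitrophenyl cannot be told apart here. The value of compound 3 is a limit and not a number: the limit of > 100000 nM in this assay, at which 1 of the 4 values shown sits.

As far as these compounds go, how far compound 3 truly lies from the others stays open. So does whether a methyl ester or a primary amide on this carbon would behave like carboxy or like methyl.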